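The source may hold more compounds than are shown below. What is called first, only, known or untested is meant among the compounds shown, and "the series" means these compounds.

Measured compounds:
- Compound 1, `CC(=O)c1cccc(Nc2cc(C)nc(-c3ccncc3)n2)c1`: 29000 nM
- Compound 2, `CC(=O)c1cc(Nc2cc(C)nc(-c3ccncc3)n2)ccc1F`: 23000 nM
- Compound 3, `CCOC(=O)c1ccc(Nc2ccnc(-c3cccnc3)n2)cc1`: 61000 nM

In a physicochemical assay for solubility, in phosphate buffer (a lower number here means a less soluble compound, a higher number a more soluble compound), compound 1 gives 29000 nM and compound 2 gives 23000 nM. The two differ by one change, (fluoro in place of hydrogen on an aromatic carbon), and the step is a 1.3-fold lower number from compound 1 to compound 2 (0.10 log units; within the scatter), so the two values cannot be told apart. Compound 3 sits on a different core, and the difference between the two cores is not broken down here; in this assay compound 3 gives 61000 nM, the highest of the three numbers, with compound 1 the nearest and compound 2 the furthest of the other two, both beyond the scatter.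

Compound 4, `CCOC(=O)c1ccc(Nc2ccnc(-c3cccnc3)n2)c(F)c1`, has not yet been measured. It is made from compound 3 by fluoro in place of hydrogen on an aromatic carbon. For the measured compounds named here, this is the same kind of change as the one from compound 1 to compound 2, though not the same: in compound 2 the fluoro stands ortho to an acetyl group and para to a large group, whereas in compound 4 it stands ortho to a large group and meta to an ethoxycarbonyl group. Because the earlier step was a 1.3-fold lower number from compound 1 to compound 2 (0.10 log units; within the scatter), the same kind of change on compound 3 is expected to give a step of about a 1.2-fold lower number from compound 3 to compound 4 (0.09 log units; within the scatter), within the scatter. Compound 4 is therefore estimated at 50000 nM, with a likely range of 25000 nM to 100000 nM, resting on a single earlier example.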

Compound 4, solubility: 53000 nM
The estimate for compound 4 lay 1.1-fold (0.03 log units) below the measured number, within the range that was stated.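

In this assay, the new step is a 1.2-fold lower number from compound 3 to compound 4 (0.06 log units; within the scatter) and lies within the scatter, as does the earlier step of the same kind, a 1.3-fold lower number from compound 1 to compound 2 (0.10 log units; within the scatter), so on each of the two cores the values on either side of fluoro in place of hydrogen on an aromatic carbon cannot be told apart. This shows that, across these two pairs, the change carried from the core of compound 1 to the core of compound 3 without a step beyond the scatter; it does not show a rule for the series, since two pairs are few and the fluoro in compound 4, ortho to a large group and meta to an ethoxycarbonyl group, does not stand where it stands in compound 2, so the effects of place and core are not separated. No measurement shown here bears on what lies behind the size of these steps.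

The compounds shown leave open whether an amine or a longer chain in place of the fluoro on the same aromatic carbon would also give a step within the scatter. They also leave open how the fluoro step would read on a core carrying a carboxylic acid in place of the ethoxycarbonyl group.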